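Removing the Amino Group from Compound 1

The source may report more compounds than this note shows. Statements on the series, on what has been measured and on what is new or still open speak of the compounds shown alone.

Compound 1 `CCCCCCCCCCCC(=O)N[C@H](CCC(=O)NC(CCCC(N)C(=O)O)C(=O)O)C(=O)O` gives 0.027 nM in a functional assay on HEK293 cells for agonist activity at Nucleotide-binding oligomerization domain-containing protein 1 (Homo sapiens), read by spectrophotometry (a higher number here means that more compound is needed for the effect, a lower number that less compound is needed), the lowest number among the three measured compounds. Compound 2 `CCCCCCCCCCCC(=O)N[C@H](CCC(=O)NC(CCCC(N)C(=O)O)C(=O)O)C(=O)OCC` gives 0.069 nM and compound 3 `CCCCCCCCCCCC(=O)NCCCC(=O)NC(CCCC(N)C(=O)O)C(=O)O` gives 0.504 nM, so the steps of a 2.6-fold higher number from compound 1 to compound 2 (0.41 log units; beyond the scatter) and a 19-fold higher number from compound 1 to compound 3 (1.27 log units; beyond the scatter) both move away from compound 1. Compound 4 `CCCCCCCCCCCC(=O)N[C@H](CCC(=O)NC(CCCCC(=O)O)C(=O)O)C(=O)O` differs from compound 1 by hydrogen in place of amino on a saturated chain carbon bound to a carbonyl carbon and a saturated chain carbon. Within the data shown here, no measured step touches this place; the closest analogy is the removal of a carboxy group in the step from compound 1 to compound 3, which was large, whereas the ester step from compound 1 to compound 2 was modest. A loss beyond the scatter is therefore expected, of about a 30-fold higher number from compound 1 to compound 4 (1.47 log units; beyond the scatter). Compound 4 is estimated at 0.8 nM, within 0.1 nM to 8 nM.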

Compound 4, half-maximal effective concentration: > 100 nM
Compound 4 gave a limit, no number; the forecaster's own chance of this, stated with the estimate: 10%; middle value at least 120-fold (2.09 log units) away from the limit.
By their numbers in this assay, from the lowest: compound 1; then compound 2; then compound 3. At a limit, above all of these: compound 4.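

In this assay compound 4 gives > 100 nM, which is a limit of the assay and not a number. Going from 3-amino-3-carboxypropyl to 3-carboxypropyl gives an at least 3700-fold higher number from compound 1 to compound 4 (3.56 log units; beyond the scatter), a larger step than the earlier 19-fold higher number from compound 1 to compound 3 (1.27 log units; beyond the scatter) or a 2.6-fold higher number from compound 1 to compound 2 (0.41 log units; beyond the scatter), so among the places changed so far this amino group is the one the result depends on most. The true size of the step stays open: the limit of > 100 nM in this assay, at which 1 of the 4 values shown sits.

The compounds shown leave open whether a methylamino group or a hydroxyl group on this same saturated chain carbon would bring the number back down. They also leave open whether the carboxylic acid on that carbon matters as much as the amino group.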